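Moving the methoxy group on the amide's phenyl ring

The source may hold more compounds than are shown below. What is called first, only, known or untested is meant among the compounds shown, and "the series" means these compounds.

Values in a functional assay on Huh-7 cells (Homo sapiens) for inhibition, read by MTT assay, with a stated time of 48 h (a higher number here means a weaker inhibitor, a lower number a stronger inhibitor), are as follows:
- compound 1 `COc1ccc2c(=O)c(/C=C/C(=O)NCc3ccccc3)coc2c1` gives 13600 nM
- compound 2 `COc1cccc(NC(=O)/C=C/c2coc3cc(OC)ccc3c2=O)c1` gives 11100 nM

These two values lie within the scatter of each other, so compound 2 cannot be separated from compound 1. The change to compound 3 `COc1ccc(NC(=O)/C=C/c2coc3cc(OC)ccc3c2=O)cc1` is 4-methoxyphenyl in place of 3-methoxyphenyl on an amide-type nitrogen and amounts to 4-methoxyphenyl in place of 3-methoxyphenyl on an amide-type nitrogen. Going by the values given here, the only measured step on this nitrogen is a 1.2-fold lower number from compound 1 to compound 2 (0.09 log units; within the scatter) and it stayed small, although it involved a different swap. No step beyond the scatter is therefore expected in this assay and the estimated 1.1-fold higher number from compound 2 to compound 3 (0.03 log units; within the scatter) is correspondingly small. Expected for compound 3 is 12000 nM with 5500 nM to 25000 nM as its range.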

Compound 3, half-maximal inhibitory concentration: > 100000 nM
Compound 3 ended at the assay's limit; the forecaster's own chance of this, stated with the estimate: 5%; middle value at least 8.3-fold (0.92 log units) from the limit.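

Swapping 3-methoxyphenyl for 4-methoxyphenyl on the amide-type nitrogen, with the same atoms joined differently, gives an at least 9.0-fold higher number from compound 2 to compound 3 (0.95 log units; beyond the scatter), so in this assay the placement of the methoxy group matters in a way the earlier swap did not reveal. Against the benzyl compound, the change is an at least 7.3-fold higher number from compound 1 to compound 3 (0.86 log units; beyond the scatter). Compound 3 is reported only as a limit, not as a number: the limit of > 100000 nM in this assay, at which 1 of the 3 values shown sits.

As far as these compounds go, how far compound 3 lies past that limit stays open. So does whether 4-fluorophenyl or 4-aminophenyl on this nitrogen would behave like 4-methoxyphenyl or like 3-methoxyphenyl.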